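This account rests on a few compounds, and the source may have more. Where it says the series, first, only, none or still open, it means among the compounds named here.

Two close relatives share a core and differ only in the group on a saturated chain carbon bound to an oxygen next to a carbonyl group. In a functional assay on HeLa cells (Homo sapiens) for cytotoxicity (on this read-out lower numbers stand for higher toxicity in this test and higher numbers for lower toxicity in this test), compound 1 `COCCOC(=O)C(O)Cn1cnc2c(N)ncnc21` gives only a limit, > 400 ug/mL, and not a number. Compound 2 `Nc1ncnc2c1ncn2CC(O)C(=O)OCc1ccco1` gives 40 ug/mL in this assay; this is the only actual number shown. The other value is the limit at which compound 1 sits (the limit of > 400 ug/mL in this assay, at which 1 of the 2 values shown sits). Among the compounds with values here, the one measured step, an at least 10-fold lower number from compound 1 to compound 2 (1.00 log units; beyond the scatter), thus runs towards higher toxicity. Compound 3 `CC(C)COC(=O)C(O)Cn1cnc2c(N)ncnc21` is not yet measured; it differs from compound 2 as follows: isopropyl in place of furan-2-yl on a saturated chain carbon bound to an oxygen next to a carbonyl group. The ring that entered in the measured step leaves again, and a branched chain enters in its place. Since that step was an at least 10-fold lower number from compound 1 to compound 2 (1.00 log units; beyond the scatter), a move back in the opposite direction, towards a higher number, is expected, though isopropyl is a different chain and the step may well be smaller. Compound 3 is therefore expected to give about 200 ug/mL in this assay, with a range from 60 ug/mL to 400 ug/mL. The expected step is a 5.0-fold higher number from compound 2 to compound 3 (0.70 log units; beyond the scatter).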

Compound 3, minimum cytotoxic concentration: > 400 ug/mL
Compound 3 was reported as a limit (the forecaster's own chance of this, stated with the estimate: 35%); at least 2.0-fold (0.30 log units) between middle value and limit.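

Swapping the furan-2-yl ring for isopropyl, on a saturated chain carbon bound to an oxygen next to a carbonyl group, gives an at least 10-fold higher number from compound 2 to compound 3 (1.00 log units; beyond the scatter) in this assay, so a second replacement, and not only methoxymethyl, loses the toxicity seen with compound 2. Compound 2 thus remains the only one of the three with an actual number, while compound 1 and compound 3 each give only a limit, and it is the same limit: the limit of > 400 ug/mL in this assay, at which 2 of the 3 values shown sit. The step between compound 1 and compound 3 cannot be read, so these two groups cannot be ranked against each other, and how far either lies from the toxicity of compound 2 has no upper bound.

With one ring-bearing compound among the three, the compounds shown leave open whether any ring at this place gives the lower number or whether it takes furan-2-yl itself, which a phenyl or a thiophen-2-yl group could begin to separate. They also leave open whether a chain can do the same, as a longer chain such as n-hexyl, or an amine, might show.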